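Methoxy for chloro in a pyridone amide series

The compounds below may be only part of what the source reports. "The series", "measured", "known", "first", "only" and "open" are said of these compounds alone.

Three compounds sharing one core were tested in a functional assay on PC-3 cells (Homo sapiens) for cytotoxicity, read by MTT assay, with a stated time of 72 h; a lower number here means a stronger inhibitor, a higher number a weaker inhibitor. Compound 1 `O=C(Nc1ccc(Oc2ccnc3[nH]ccc23)cc1)c1nn(-c2ccc(Cl)cc2)ccc1=O` gives 32400 nM in this assay. Compound 3 `O=C(Nc1ccc(Oc2ccnc3[nH]ccc23)c(F)c1)c1nn(-c2ccc(Cl)cc2)ccc1=O` differs from compound 1 by fluoro in place of hydrogen on an aromatic carbon. In this assay compound 3 gives 42500 nM; the step is a 1.3-fold higher number from compound 1 to compound 3 (0.12 log units; within the scatter). Compound 2 `COc1ccc(-n2ccc(=O)c(C(=O)Nc3ccc(Oc4ccnc5[nH]ccc45)cc3)n2)cc1` carries the change methoxy in place of chloro on an aromatic carbon relative to compound 1. In this assay compound 2 gives > 60000 nM, which is a limit of the assay rather than a number. The step recorded is an at least 1.8-fold higher number from compound 1 to compound 2 (0.26 log units; that floor lies within the scatter), resting on (the limit of > 60000 nM in this assay, at which 1 of the 3 values shown sits). Compound 4 `COc1ccc(-n2ccc(=O)c(C(=O)Nc3ccc(Oc4ccnc5[nH]ccc45)c(F)c3)n2)cc1` carries the same change from compound 3, (methoxy in place of chloro on an aromatic carbon). In this assay a step of a 2.0-fold higher number from compound 3 to compound 4 (0.30 log units; within the scatter) is expected, beside the earlier one, because the earlier pair showed an at least 1.8-fold higher number from compound 1 to compound 2 (0.26 log units; that floor lies within the scatter). Compound 4 is therefore estimated at 85000 nM in this assay, with a range from 45000 nM to 200000 nM.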

Compound 4, half-maximal inhibitory concentration: 46400 nM
Estimate against measurement, compound 4: 1.8-fold (0.26 log units) above; measured number inside the range.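

On the core carrying the added fluoro, methoxy in place of chloro gives a 1.1-fold higher number from compound 3 to compound 4 (0.04 log units; within the scatter) in this assay, so no effect of the change can be read on this core. Set beside the core of compound 1, this neither confirms nor rules out that the change carries over between cores: the same change on two cores in this assay, an at least 1.8-fold higher number (0.26 log units; that floor lies within the scatter) from compound 1 to compound 2 and a 1.1-fold higher number (0.04 log units; within the scatter) from compound 3 to compound 4; the limit leaves it open whether they differ. The fluoro change, read on the methoxy compounds as an at least 1.2-fold lower number from compound 2 to compound 4 (0.11 log units; that floor lies within the scatter), is equally unresolved, since the value of compound 2 is a limit of the assay: the same change on two cores in this assay, a 1.3-fold higher number (0.12 log units; within the scatter) from compound 1 to compound 3 and an at least 1.2-fold lower number (0.11 log units; that floor lies within the scatter) from compound 2 to compound 4; the limit leaves it open whether they differ.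

The compounds shown leave open whether any group at this position could give a step beyond the scatter. An amine, a carboxylic acid or a longer alkoxy chain in place of the chloro of the 4-chlorophenyl group would address this.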